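Working notes on compounds 1 to 3

A few compounds are considered here, and "the series" means these few. Any claim that something is new, unique, unknown or untested is made for them only; others in the source may bear on it.

Measured in a functional assay on Ehrlich cells (Mus musculus) for cytotoxicity, read by trypan blue exclusion, with a stated time of 2 h; a lower number here means a stronger inhibitor, a higher number a weaker inhibitor:
compound 1 `N#CC1=C(NC(=S)Nc2ccccc2)N(c2ccc(S(N)(=O)=O)cc2)C2=C(C(=O)CCC2)C1c1ccc(Cl)cc1Cl` — 25 ug/mL
compound 2 `N#CC1=C(NC(=S)Nc2ccc(Br)cc2)N(c2ccc(S(N)(=O)=O)cc2)C2=C(C(=O)CCC2)C1c1ccc(Cl)cc1Cl` — 25 ug/mL

Compound 2 stands level with compound 1 at the digits shown; the single step seen so far, no change at the digits printed from compound 1 to compound 2 (within the scatter), bromo in place of hydrogen on an aromatic carbon, lies within the scatter. Compound 3 `N#CC1=C(NS(=O)(=O)c2ccc([N+](=O)[O-])cc2)N(c2ccc(S(N)(=O)=O)cc2)C2=C(C(=O)CCC2)C1c1ccc(Cl)cc1Cl` differs from compound 2 by a group of 12 heavy atoms (6 carbon, 1 nitrogen, 4 oxygen, 1 sulfur; one six-membered aromatic ring of carbon only) in place of a group of 10 heavy atoms (7 carbon, 1 nitrogen, 1 sulfur, 1 bromine; one six-membered aromatic ring of carbon only), on an amine nitrogen. Within the data shown here, no measured step touches that amine nitrogen, and the one step on record was flat, so nothing known points up or down. For compound 3 the value in this assay is estimated at 25 ug/mL, range 8 ug/mL to 80 ug/mL. The expected step of no change at the digits printed from compound 2 to compound 3 (within the scatter) is thus taken as none beyond the scatter, with wide uncertainty.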

Compound 3, half-maximal inhibitory concentration: 20 ug/mL
For compound 3 the middle estimate is 1.3-fold (0.10 log units) above the measured one; measured number inside the range.
By their numbers in this assay, from the lowest: compounds 3, 1 and 2 (each within the scatter of the next).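

In this assay, among these compounds, the first change on the amine nitrogen puts (4-nitrophenyl)sulfonyl in place of the group of 10 heavy atoms, giving a 1.3-fold lower number from compound 2 to compound 3 (0.10 log units; within the scatter). Replacing the same group without its bromo gives a 1.3-fold lower number from compound 1 to compound 3 (0.10 log units; within the scatter), so both exchanges at this position stay within the scatter, whereas the earlier step only altered the far aromatic ring. No supporting measurement bears on this result.

Going by these compounds, whether a much smaller group on this nitrogen, such as a free amine or an acetyl, would shift the value remains open. So does whether a carboxylic acid on the sulfonyl-bearing ring would.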